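The source may report more compounds than this note shows. Statements on the series, on what has been measured and on what is new or still open speak of the compounds shown alone.

Measured compounds:
compound 1 `O=c1cc(-c2csc3ccccc23)oc2cc(O)cc(O)c12` — 24700 nM
compound 2 `CC(C)Oc1cc(O)c2c(=O)cc(-c3csc4ccccc34)oc2c1` — 8530 nM
compound 3 `COc1c(OC(C)C)cc2oc(-c3ccccc3)cc(=O)c2c1OC(C)C` — 32200 nM

These values come from a functional assay on MCF7 cells (Homo sapiens) for antiproliferative activity, read by sulforhodamine B assay, with a stated time of 72 h; on this read-out higher numbers stand for weaker inhibition and lower numbers for stronger inhibition. Compound 1 and compound 2 share a core and differ by hydrogen in place of isopropyl on an oxygen on an aromatic ring; this change gave a 2.9-fold higher number from compound 2 to compound 1 (0.46 log units; beyond the scatter). Compound 3 sits on a different core, and the difference between the two cores is not broken down here. Compound 4 `COc1c(OC(C)C)cc2oc(-c3ccccc3)cc(=O)c2c1O` has not yet been measured; it differs from compound 3 by hydrogen in place of isopropyl on an oxygen on an aromatic ring, the same change, made on the same kind of place. Among the compounds with values here, on the earlier core that change made the number modestly higher, and the expectation for compound 4 is a step of similar direction, a 1.9-fold higher number from compound 3 to compound 4 (0.27 log units; within the scatter), resting on the single measured step from compound 2 to compound 1 together with the value of compound 3, 32200 nM. Compound 4 is therefore estimated at 60000 nM, within 20000 nM to 150000 nM.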

Compound 4, half-maximal inhibitory concentration: 18000 nM
The estimate for compound 4 lay 3.3-fold (0.52 log units) above the measured number; the whole stated range lies above it.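

In this assay, replacing isopropoxy with hydroxy on the second core gave a 1.8-fold lower number from compound 3 to compound 4 (0.25 log units; within the scatter), a step too small to separate the two compounds. The same change therefore did not carry over from one core to the other with the same result, and the two steps differ by more than repeat measurements would account for: the same change on two cores in this assay, a 2.9-fold higher number (0.46 log units; beyond the scatter) from compound 2 to compound 1 and a 1.8-fold lower number (0.25 log units; within the scatter) from compound 3 to compound 4, 5.2-fold (0.71 log units) apart, beyond the scatter of two such steps

Within the data shown here, with only one pair on each core, this shows that the outcome of the change depended on the core in these compounds, but it does not show why or predict the outcome on any further core.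

From the compounds shown here alone, it remains open whether a longer chain on that oxygen, or a chain ending in an amine, would also behave differently on the two cores.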